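The source may report more compounds than this note shows. Statements on the series, on what has been measured and on what is new or still open speak of the compounds shown alone.

Measured compounds:
Compound 1 `O=C(Nc1ccc(Cl)c(-c2nnc3c(Cl)cccn23)c1)c1ccc(C(F)(F)F)cc1Cl` — in a functional assay on U-251 cells (Homo sapiens) for antiproliferative activity, read by MTT assay, with a stated time of 72 h (a higher number here means a weaker inhibitor, a lower number a stronger inhibitor), compound 1 gives > 100000 nM, which is a limit of the assay and not a number.
Compound 2 `O=C(Nc1ccc(Cl)c(-c2nnc3c(Cl)cccn23)c1)c1cccnc1` — in this assay compound 2 gives > 100000 nM, likewise a limit.
Compound 3 `O=C(Nc1ccc(Cl)c(-c2nnc3c(Cl)cccn23)c1)c1cccc(Cl)c1` — in this assay compound 3 gives 43100 nM.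

Among the compounds with values here, compound 3 therefore stands as the only compound with a measured number; the two others sit at a limit. Within the data shown here, the one step that can be read is an at least 2.3-fold lower number from compound 2 to compound 3 (0.36 log units; beyond the scatter), in which 3-chlorophenyl replaced pyridin-3-yl on the carbonyl carbon and the number fell.

Compound 4 `O=C(Nc1ccc(Cl)c(-c2nnc3c(Cl)cccn23)c1)c1ccon1` is not yet measured. It differs from compound 3 in one place: 1,2-oxazol-3-yl in place of 3-chlorophenyl on a carbonyl carbon. This is the counterpart of the measured step, a carbon-only six-membered ring giving way to a small heteroaromatic ring on the same carbonyl carbon. The step from compound 2 to compound 3 ran the other way and was at least modest, so for compound 4 the number in this assay is expected to rise rather than fall, with a step of about a 2.3-fold higher number from compound 3 to compound 4 (0.37 log units; beyond the scatter). Because (the limit of > 100000 nM in this assay, at which 2 of the 3 values shown sit), a limit rather than a number is the likelier outcome. Compound 4 is estimated at 100000 nM, within a range from 30000 nM to 300000 nM.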

Compound 4, half-maximal inhibitory concentration: > 100000 nM
Compound 4 gave a limit, no number (the forecaster's own chance of this, stated with the estimate: 55%); the middle value sits exactly at the limit.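

In this assay, 1,2-oxazol-3-yl in place of 3-chlorophenyl on the carbonyl carbon gives an at least 2.3-fold higher number from compound 3 to compound 4 (0.36 log units; beyond the scatter), so a five-membered aromatic ring with 2 hetero atoms now joins the six-membered pyridin-3-yl ring in leaving no measured number. The result for compound 4 is a limit, as is that of compound 2, and the step between these two compounds cannot be read. Compound 3 therefore remains the only compound with a number, while compound 1, which also has a six-membered aromatic ring of carbon only, goes against any reading that such a ring alone is enough to give a number, and most of the results at this position stay out of numerical reach: the limit of > 100000 nM in this assay, at which 3 of the 4 values shown sit.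

The compounds shown leave open what an unsubstituted phenyl group on this carbonyl carbon would give, and so whether the chlorine of compound 3 matters to its number. They also leave open how a phenyl ring carrying an amine or a carboxylic acid, or a saturated cyclohexyl ring, would read in this assay.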